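The source may hold more compounds than are shown below. What is called first, only, known or untested is meant among the compounds shown, and "the series" means these compounds.

The series keeps the core of compound 1 `COc1ccc(/C(=N\O)c2ccc3c(ccn3C)c2)c(OC)c1OC` and varies the substituent on the double-bonded nitrogen. In a functional assay on A549 cells (Homo sapiens) for cytotoxicity, read by XTT assay, with a stated time of 72 h (a higher number here means a weaker inhibitor, a lower number a stronger inhibitor), compound 1 gives 1000 nM. Compound 2 `COc1ccc(/C(=N\OC(C)=O)c2ccc3c(ccn3C)c2)c(OC)c1OC` carries acetyl in place of hydrogen on an oxygen; in this assay compound 2 reaches only the limit of > 10000 nM. Compound 3 `COc1ccc(/C(=N\N)c2ccc3c(ccn3C)c2)c(OC)c1OC` carries amino in place of hydroxy; in this assay compound 3 likewise stands at the limit of > 10000 nM, so no number is known for it. The steps of an at least 10-fold higher number from compound 1 to compound 2 (1.00 log units; beyond the scatter) and an at least 10-fold higher number from compound 1 to compound 3 (1.00 log units; beyond the scatter) both run toward weaker inhibition, while the step that the two limits leave unreadable from compound 2 to compound 3 cannot be read. Compound 4 `COc1ccc(/C(=N\NC(C)=O)c2ccc3c(ccn3C)c2)c(OC)c1OC` differs from compound 3 by acetyl in place of hydrogen on an amine nitrogen, the same kind of acylation seen between compound 1 and compound 2. Given (the limit of > 10000 nM in this assay, at which 2 of the 3 values shown sit), compound 4 is expected to stay at that limit, the expected step being a step that the limit leaves unreadable from compound 3 to compound 4. Compound 4 is therefore estimated at 15000 nM, with a range of 5000 nM to 50000 nM.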

Compound 4, half-maximal inhibitory concentration: > 10000 nM
Compound 4: only a limit was reported; the forecaster's own chance of this, stated with the estimate: 80%; the middle value is on the limit's open side.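

In this assay, the replacement of hydroxy on the double-bonded nitrogen gains a third case, with an at least 10-fold higher number from compound 1 to compound 4 (1.00 log units; beyond the scatter). Acetyl on the amine nitrogen of compound 3 brings back no readable value, and compound 4 stands at a limit, not a number. Every replacement of hydroxy shown ends at the same limit: the limit of > 10000 nM in this assay, at which 3 of the 4 values shown sit.

The steps among compound 2, compound 3 and compound 4 cannot be read, so these three stay unranked. Going by these compounds, whether a methyl group or a longer chain on the oxygen keeps a readable value remains open.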